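Isopropyl in place of trifluoromethyl on a receptor agonist

The source may hold more compounds than are shown below. What is called first, only, known or untested is meant among the compounds shown, and "the series" means these compounds.

Compound 1 `CC#CC(CC(=O)O)c1ccc(OCc2ccc3nc(-c4ccc(C(F)(F)F)cc4)cn3c2)cc1` is tested in an assay on isolated protein for agonist activity at Free fatty acid receptor 1 (Homo sapiens) (on this read-out lower numbers stand for an effect already at smaller amounts and higher numbers for an effect only at larger amounts of compound), where it gives 558 nM. Compound 3 `CC#CC(CC(=O)O)c1ccc(OCc2ccn3cc(-c4ccc(C(C)C)cc4)nc3c2)cc1` gives 615 nM, which is within the usual scatter of compound 1, while compound 2 `CC#CC(CC(=O)O)c1ccc(OCc2ccn3cc(-c4ccccc4)nc3c2)cc1` gives 1260 nM, a number clearly apart from compound 1. Compound 4 `CC#CC(CC(=O)O)c1ccc(OCc2ccc3nc(-c4ccc(C(C)C)cc4)cn3c2)cc1` differs from compound 1 by isopropyl in place of trifluoromethyl on an aromatic carbon. For the measured compounds named here, no measured pair covers this exact change. Going by the values given here, the one measured step that involves isopropyl, a 2.0-fold lower number from compound 2 to compound 3 (0.31 log units; beyond the scatter), goes from hydrogen rather than from trifluoromethyl. Compound 3 carries isopropyl on a different core and lands within the scatter of compound 1, so no step beyond the scatter is expected. Compound 4 is therefore estimated at 550 nM in this assay, within 280 nM to 1100 nM, a step of a 1.0-fold lower number from compound 1 to compound 4 (0.01 log units; within the scatter).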

Compound 4, half-maximal effective concentration: 528 nM
Estimate against measurement, compound 4: 1.0-fold (0.02 log units) above; low and high end bracket the measured number.
By their numbers in this assay, from the lowest: compounds 4, 1 and 3 (each within the scatter of the next); then compound 2.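

Measured directly on one core, the change from 4-(trifluoromethyl)phenyl to 4-isopropylphenyl in this assay gives a 1.1-fold lower number from compound 1 to compound 4 (0.02 log units; within the scatter) and so leaves the read-out within the scatter. Earlier, isopropyl could be compared only with hydrogen on a different core; here it can be compared with trifluoromethyl, and at this place the two groups cannot be told apart. No available evidence explains this match.

Still open, from the compounds shown here alone, is whether an amine or a methoxy group at this place would read the same. Also open, going by these compounds, is whether hydrogen there, on the core of compound 1, would stand clearly apart from both groups.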